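The source may report more compounds than this note shows. Statements on the series, on what has been measured and on what is new or still open speak of the compounds shown alone.

Measured so far in a functional assay on HT-29 cells (Homo sapiens) for inhibition, read by sulforhodamine B assay, with a stated time of 48 h; on this read-out lower numbers stand for stronger inhibition of growth and higher numbers for weaker inhibition of growth:
compound 1, `CCc1ccc(NC(=S)N/N=C/c2cccs2)cc1` — > 100000 nM
compound 2, `S=C(N/N=C/c1cccs1)Nc1cccnc1` — > 100000 nM
compound 3, `C=CCNC(=S)N/N=C/c1cccs1` — > 100000 nM

None of these three values is a true number. For compound 1 the value > 100000 nM is a limit of the assay, not a number. The same is true of compound 2, whose value > 100000 nM is a limit. It is true as well of compound 3, whose value > 100000 nM is a limit. Compound 1 therefore cannot be placed above or below its two companions; all that can be said is that it sits, with them, at the limit of > 100000 nM in this assay, at which 3 of the 3 values shown sit.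

Compound 4, `COc1ccc(NC(=S)N/N=C/c2cccs2)cc1`, has not yet been tested. It differs from compound 1 in one place: methoxy in place of ethyl on an aromatic carbon. Within the data shown here, because every value shown sits at the limit of > 100000 nM in this assay, at which 3 of the 3 values shown sit, the three measured compounds give no step of known size, and nothing here shows how far an exchange of this kind moves this read-out. The expected step is a number no higher from compound 1 to compound 4 (the limit leaves the size open), none beyond the scatter. Compound 4 is accordingly estimated at 100000 nM, within a range from 30000 nM to 300000 nM, and most likely reported once more as a limit rather than a number.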

Compound 4, concentration for 50% growth inhibition: > 100000 nM
Compound 4 was reported as a limit (the forecaster's own chance of this, stated with the estimate: 85%); the middle value lies on the limit itself.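

No new step can be read from compound 1 to compound 4, because the exchange of ethyl for methoxy leaves both compounds at a limit of the assay and not at a number: the limit of > 100000 nM in this assay, at which 4 of the 4 values shown sit. The compounds shown leave open how strongly, if at all, any of them inhibits growth of these cells.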